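The source may hold more compounds than are shown below. What is called first, only, known or untested is meant among the compounds shown, and "the series" means these compounds.

Four compounds are considered here, each built on a closely related core. Compound 1 `OCCOCn1c(S)nc2c(Cl)cc(Cl)cc21` bears a sulfanyl group, and compound 2 `OCCOCn1c(S)nc2c(Cl)c(Cl)ccc21` is made of the same atoms joined differently; the difference between the two cores is not broken down here. Compound 3 `OCCOCn1c(Br)nc2c(Cl)cc(Cl)cc21` is derived from compound 1 by bromo in place of sulfanyl on an aromatic carbon. Compound 4 `OCCOCn1c(Br)nc2c(Cl)c(Cl)ccc21`, which has not yet been measured, is derived from compound 2 by bromo in place of sulfanyl on an aromatic carbon. The two place descriptions agree word for word, so the change from compound 2 to compound 4 is the same change as that from compound 1 to compound 3.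

In a functional assay on KB cells (Homo sapiens) for inhibition (on this read-out lower numbers stand for stronger inhibition and higher numbers for weaker inhibition), compound 1 reaches only the limit of the assay at > 100000 nM. In this assay compound 2 likewise gives only the limit at > 100000 nM. In this assay compound 3 also stops at the limit at > 100000 nM. The step from compound 1 to compound 3 is thus a step that the two limits leave unreadable from compound 1 to compound 3; all the measurements offer is the limit of > 100000 nM in this assay, at which 3 of the 3 values shown sit.

Compound 4 is expected to stay at the limit as well because the same change gave a step that the two limits leave unreadable from compound 1 to compound 3, so the expected step is a step that the limit leaves unreadable from compound 2 to compound 4. The estimate for compound 4 in this assay is 200000 nM, with an expected range from 50000 nM to 1000000 nM.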

Compound 4, half-maximal inhibitory concentration: > 100000 nM
Compound 4: a limit, no number; the forecaster's own chance of this, stated with the estimate: 85%; the middle value does not contradict the limit.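

Compound 4 gives only a limit in this assay, as do compound 1, compound 2 and compound 3, so no step between compound 2 and compound 4 or between compound 1 and compound 3 can be read: the limit of > 100000 nM in this assay, at which 4 of the 4 values shown sit.

The compounds shown leave open whether bromo in place of sulfanyl changes inhibition at all, and whether the two cores differ in this assay.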